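Bromo to hydrogen on the shared core, second ring size

The source may report more compounds than this note shows. Statements on the series, on what has been measured and on what is new or still open speak of the compounds shown alone.

Compound 1 `FC(F)(F)c1cc(-n2cc(CN3CCCN(c4noc5ccccc45)CC3)nn2)ccc1Br`, compound 2 `FC(F)(F)c1cc(-n2cc(CN3CCN(c4noc5ccccc45)CC3)nn2)ccc1Br` and compound 3 `FC(F)(F)c1cccc(-n2cc(CN3CCCN(c4noc5ccccc45)CC3)nn2)c1` were measured in an ADME assay on RAW264.7 cells (Mus musculus) for inhibition, with a stated time of 72 h; on this read-out lower numbers stand for stronger inhibition and higher numbers for weaker inhibition. In this assay compound 1 gives 181000 nM, compound 2 gives 223000 nM and compound 3 gives 178000 nM. Compound 2 carries the largest number of the three, but its gaps to compound 1 and to compound 3 are both within the scatter, so the three compounds cannot be told apart on these numbers. Compound 4 `FC(F)(F)c1cccc(-n2cc(CN3CCN(c4noc5ccccc45)CC3)nn2)c1` is not yet measured. It differs from compound 2 in one place: hydrogen in place of bromo on an aromatic carbon. The same exchange has already been seen once, on the core with the larger saturated ring, where the step of a 1.0-fold lower number from compound 1 to compound 3 (0.01 log units; within the scatter) did not move the number beyond the scatter. On the strength of that step, compound 4 is expected to sit close to compound 2, with a step of a 1.0-fold lower number from compound 2 to compound 4 (0.02 log units; within the scatter) and no change beyond the scatter. The estimate for compound 4 in this assay is 215000 nM, within a range from 110000 nM to 430000 nM.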

Compound 4, half-maximal inhibitory concentration: 305000 nM
Estimate against measurement, compound 4: 1.4-fold (0.15 log units) below, within the range that was stated.
By their numbers in this assay, from the lowest: compounds 3, 1, 2 and 4 (each within the scatter of the next).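

In this assay, hydrogen in place of bromo on this aromatic carbon, ortho to a trifluoromethyl group and para to a large group, can now be read on both cores, and the second reading also stays within the scatter (a 1.4-fold higher number from compound 2 to compound 4 (0.14 log units; within the scatter)). One reading on a single core could have been particular to that core, but the exchange now leaves the number inside the scatter on the core of compound 1 and on the core of compound 2. The two steps also agree with each other: the same change on two cores in this assay, a 1.0-fold lower number (0.01 log units; within the scatter) from compound 1 to compound 3 and a 1.4-fold higher number (0.14 log units; within the scatter) from compound 2 to compound 4, 1.4-fold (0.14 log units) apart, within the scatter of two such steps.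

The compounds shown leave open whether anything at this position can move the number beyond the scatter, since only bromo and hydrogen stand there. A methoxy group, an amine or a carboxylic acid on the same carbon would put this to the test.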